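A few compounds are considered here, and "the series" means these few. Any claim that something is new, unique, unknown or untested is made for them only; others in the source may bear on it.

Compound 3 `CC(C)N1CCc2nc(C#Cc3ccccc3)ccc2C1=O` gives 706 nM in a functional assay on HEK293 cells for negative allosteric modulation of metabotropic glutamate receptor 5 (Homo sapiens), read by FLIPR and calcium flux; a higher number here means a weaker inhibitor, a lower number a stronger inhibitor. Compound 1 `Cc1ccc(C#Cc2ccc3c(n2)CCN(C)C3=O)cc1` gives 1400 nM in this assay and compound 2 `CN1CCc2nc(C#Cc3ccc(Cl)cc3)ccc2C1=O` gives 352 nM. The number for compound 3 sits within the scatter of both compound 1 and compound 2, so on the three numbers it is not set apart from either. Among the measured compounds shown here, the one measured step, chloro in place of methyl on an aromatic carbon, is a 4.0-fold lower number from compound 1 to compound 2 (0.60 log units; beyond the scatter).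

Compound 4 `CC(C)N1CCc2nc(C#Cc3cccc(Cl)c3)ccc2C1=O` differs from compound 3 by chloro in place of hydrogen on an aromatic carbon. For the measured compounds named here, no measured pair shows hydrogen against chloro at this place. The step that bears on it, loosely, is a 4.0-fold lower number from compound 1 to compound 2 (0.60 log units; beyond the scatter): there chloro entered in place of methyl, not hydrogen, and on a pair that differs from compound 3 and compound 4 in the group on the amide nitrogen, so it can guide only the direction. On that basis the step from compound 3 to compound 4 in this assay is expected to be a lowering of modest size, about a 1.8-fold lower number from compound 3 to compound 4 (0.25 log units; within the scatter), though a result within the scatter would not be surprising. Compound 4 is therefore expected to give 400 nM, with a range from 150 nM to 1100 nM.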

Compound 4, half-maximal inhibitory concentration: 5.7 nM
Beside the measured number, compound 4's estimate is 70-fold (1.85 log units) above it; the measured number lies below the stated range.
By their numbers in this assay, from the lowest: compound 4; then compounds 2, 3 and 1 (each within the scatter of the next, the first and the last beyond it).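

In this assay, among the compounds shown here, phenyl to 3-chlorophenyl gives a 120-fold lower number from compound 3 to compound 4 (2.09 log units; beyond the scatter), so one chloro on this aromatic carbon, meta to a large group, carries far more weight than the earlier compounds suggested. For the compounds shown here, their only measured step, a 4.0-fold lower number from compound 1 to compound 2 (0.60 log units; beyond the scatter), set chloro against methyl rather than hydrogen, on a pair with a different group on the amide nitrogen, and its size gave no sign of a change this large at this place. Nothing at hand accounts for the size of the new step.

Open, on these data alone, is whether the step belongs to chloro in particular or would also appear with fluoro, bromo, methoxy or a nitrile on the same carbon. Also open, as far as these compounds go, is whether hydrogen to chloro at this place gives a step of similar size when the amide nitrogen carries methyl, as in compound 1 and compound 2, or a longer chain or a ring, and whether a second chloro on the same aromatic ring adds to the step or takes from it.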